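Swapping Trifluoromethyl for Fluoro in a Kinase Series

The compounds below may be only part of what the source reports. "The series", "measured", "known", "first", "only" and "open" are said of these compounds alone.

Of the compounds shown here, two have been measured in an assay on isolated protein for inhibition of serine/threonine-protein kinase PLK1 (Homo sapiens), read by radiometric assay and 33P incorporation, with a stated time of 40 min, tested at 20 uM, in the presence of a further agent that is not named here; on this read-out higher numbers stand for more inhibition at the one concentration tested (going by the name of the read-out) and lower numbers for less inhibition. Compound 1 `CCNc1cc(-c2ccc(NC(=O)Nc3cccc(Cl)c3)cc2C)ccn1` gives 82.7%, and compound 2 `CCNc1cc(-c2ccc(NC(=O)Nc3cccc(Cl)c3)cc2C(F)(F)F)ccn1` gives 94.9%. Going by the values given here, compound 2 therefore stands highest of the two numbers, and the only recorded step, a number 12.2 percentage points higher from compound 1 to compound 2 (beyond the scatter), lies beyond the scatter and is modest in size.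

Compound 3 `CCNc1cc(-c2ccc(NC(=O)Nc3cccc(Cl)c3)cc2F)ccn1` differs from compound 2 in one place: fluoro in place of trifluoromethyl on an aromatic carbon. Among the compounds with values here, only the step from compound 1 to compound 2 bears on this change, since it concerns the same position, where trifluoromethyl gave a modestly higher number than methyl. Fluoro at that position has not been measured, so the two known groups set the frame. Compound 3 is expected to fall by a number 9.9 percentage points lower from compound 2 to compound 3 (within the scatter), landing roughly between the two measured values. The estimate for compound 3 is 85%, with a range from 72% to 95%.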

Compound 3, a percentage reported as inhibition, at one concentration (the size of the read-out at that concentration, not a potency): 72.7%
Compound 3: middle estimate off by 12.3 percentage points, on the high side; the range from low to high includes it.
By their numbers in this assay, from the lowest: compounds 3 and 1 (each within the scatter of the next); then compound 2.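

Putting fluoro in place of trifluoromethyl, on the aromatic carbon ortho to the 2-(ethylamino)pyridin-4-yl group, gives a number 22.2 percentage points lower from compound 2 to compound 3 (beyond the scatter) in this read-out, so the higher inhibition seen with trifluoromethyl does not carry over to fluoro. Set against methyl, the same fluoro gives a number 10 percentage points lower from compound 1 to compound 3 (within the scatter) and these two groups cannot be told apart, which leaves trifluoromethyl as the only one of the three groups at this place that stands clear of both others. Nothing measured here says why trifluoromethyl stands apart. 

On these data alone, whether chloro, methoxy or an ethyl chain at this place would match trifluoromethyl remains open. As far as these compounds go, each number also comes from a single concentration, so how these compounds compare in potency remains open too.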